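A few compounds are considered here, and "the series" means these few. Any claim that something is new, unique, unknown or untested is made for them only; others in the source may bear on it.

Compound 1 `COc1ccc(N2C(=O)COc3ccc(-c4cnc(OC)c(NS(=O)(=O)c5ccc(F)cc5)c4)cc32)cc1` gives 1220 nM in a functional assay on HeLa cells (Homo sapiens) for antiproliferative activity, read by MTT assay, with a stated time of 72 h (on this read-out higher numbers stand for weaker inhibition and lower numbers for stronger inhibition), the lowest of the two numbers in the series; the nearest, compound 3 `COc1ccc(N2C(=O)COc3ccc(-c4cnc(Cl)c(NS(=O)(=O)c5ccc(F)cc5)c4)cc32)cc1`, gives 8320 nM. Compound 2 `O=C1COc2ccc(-c3ccc(O)cc3)cc2N1` returns only a limit of the assay, > 40000 nM, which is the limit of > 40000 nM in this assay, at which 1 of the 3 values shown sits. Within the data shown here, the only measured step, a 6.8-fold higher number from compound 1 to compound 3 (0.83 log units; beyond the scatter), concerns chloro in place of methoxy on an aromatic carbon and so touches a different part of the shared core from the one now altered.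

Compound 4 `COc1cccc(N2C(=O)COc3ccc(-c4cnc(OC)c(NS(=O)(=O)c5ccc(F)cc5)c4)cc32)c1` differs from compound 1 by 3-methoxyphenyl in place of 4-methoxyphenyl on an amide-type nitrogen in a ring. Among the measured compounds shown here, no measured step bears on this change, so no step beyond the scatter is expected in this assay. Compound 4 is therefore estimated at 1500 nM, with a range of 600 nM to 4000 nM. The expected step is a 1.2-fold higher number from compound 1 to compound 4 (0.09 log units; within the scatter).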

Compound 4, half-maximal inhibitory concentration: > 40000 nM
Compound 4: no number, only a limit (the forecaster's own chance of this, stated with the estimate: 3%); middle value at least 26-fold (1.42 log units) from the limit.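

In this assay, 3-methoxyphenyl in place of 4-methoxyphenyl on the amide-type nitrogen gives an at least 32-fold higher number from compound 1 to compound 4 (1.51 log units; beyond the scatter), although the two groups have the same atoms. Activity in this series therefore depends on which of these two methoxyphenyl groups sits on this nitrogen, not only on the group changed in compound 3. Compound 4 gives > 40000 nM, which is a limit of the assay and not a number, so the full size of the step stays unknown: the limit of > 40000 nM in this assay, at which 2 of the 4 values shown sit.

On these data alone, how a plain phenyl or an aminophenyl on this nitrogen would read remains open.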